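The source may hold more compounds than are shown below. What is called first, only, known or untested is meant among the compounds shown, and "the series" means these compounds.

Compound 2 `O=C(/C=C/c1cc(Br)c(Br)[nH]1)c1ccccc1` and compound 1 `Cn1c(/C=C/C(=O)c2ccccc2)cc(Br)c1Br` share a core and differ only in one place: compound 1 carries methyl in place of hydrogen on an aromatic nitrogen. In a functional assay on MCF7 cells (Homo sapiens) for cytotoxicity, read by MTT assay, with stated times of 6 h and 48 h (on this read-out higher numbers stand for weaker inhibition and lower numbers for stronger inhibition), compound 2 gives 12200 nM. In this assay compound 1 gives 35400 nM, so that a 2.9-fold higher number from compound 2 to compound 1 (0.46 log units; beyond the scatter). Compound 3 `O=c1cc(-c2cc(Br)c(Br)[nH]2)oc2ccccc12` carries a different core; how its core differs from that of compound 2 is not broken down here. In this assay compound 3 gives only a limit, >= 100000 nM, which is the assay's limit rather than a number, as the limit of >= 100000 nM in this assay, at which 1 of the 3 values shown sits, records. Compound 4 `Cn1c(-c2cc(=O)c3ccccc3o2)cc(Br)c1Br` has not yet been measured in this assay; it differs from compound 3 by methyl in place of hydrogen on an aromatic nitrogen, which is the same change that separates compound 2 from compound 1. Compound 4 is expected to sit at the limit as well, an expectation resting on compound 3 with its limit of >= 100000 nM and on the weakening seen in a 2.9-fold higher number from compound 2 to compound 1 (0.46 log units; beyond the scatter). The step estimated for compound 4 is a step that the limit leaves unreadable from compound 3 to compound 4. Compound 4 is therefore estimated at 200000 nM, with a range from 100000 nM to 500000 nM.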

Compound 4, half-maximal inhibitory concentration: >= 100000 nM
Compound 4 ended at the assay's limit; the forecaster's own chance of this, stated with the estimate: 85%; the middle value does not contradict the limit.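

In this assay compound 3 and compound 4 both end at the assay's limit and not at a number, so no step between them can be read: the limit of >= 100000 nM in this assay, at which 2 of the 4 values shown sit.

The compounds shown leave open whether methyl in place of hydrogen on an aromatic nitrogen does anything on the core of compound 3 comparable to what it does on the core of compound 2.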